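The compounds below may be only part of what the source reports. "The series", "measured", "known", "first", "only" and "open" are said of these compounds alone.

Measured compounds in a functional assay on OVCAR-5 cells (Homo sapiens) for inhibition, read by sulforhodamine B assay, with a stated time of 48 h; on this read-out higher numbers stand for weaker inhibition of growth and lower numbers for stronger inhibition of growth:
compound 1 `Nc1cc(N)c2nc(-c3ccccc3)c(NCc3ccc(Cl)c(Cl)c3)nc2c1` gives 24000 nM
compound 2 `COc1ccc(CNc2nc3cc(N)cc(N)c3nc2-c2ccccc2)cc1OC` gives 20900 nM
compound 3 `COc1cc(CNc2nc3cc(N)cc(N)c3nc2-c2ccccc2)cc(OC)c1OC` gives 21400 nM

Compound 2 carries the lowest of the three numbers, but the distance to compound 3 and to compound 1 each lies within the scatter, so the three compounds cannot be told apart in this assay. Compound 4 `COc1ccc(CNc2nc3cc(N)cc(N)c3nc2-c2ccccc2)cc1` differs from compound 2 by one change: hydrogen in place of methoxy on an aromatic carbon. The step that bears on it most directly is a 1.0-fold higher number from compound 2 to compound 3 (0.01 log units; within the scatter), a methoxy added at an aromatic carbon, and the wider swap a 1.1-fold lower number from compound 1 to compound 2 (0.06 log units; within the scatter) is likewise within the scatter. Neither change moved the number, so no step beyond the scatter is expected here, in either direction. Compound 4 is therefore estimated at 21000 nM, within 10000 nM to 45000 nM, a step of a 1.0-fold higher number from compound 2 to compound 4 (0.00 log units; within the scatter).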

Compound 4, concentration for 50% growth inhibition: 20900 nM
Compound 4: the middle estimate sits 1.0-fold (0.00 log units) above what was measured, and the stated range covers the measured number.
By their numbers in this assay, from the lowest: compounds 2, 4, 3 and 1 (each within the scatter of the next).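

In this assay, for the compounds shown here, going from 3,4-dimethoxyphenyl to 4-methoxyphenyl gives no change at the digits printed from compound 2 to compound 4 (within the scatter) and so shows that hydrogen and methoxy read alike at this position, which the earlier compounds, differing elsewhere on the ring, could not show. The 4-methoxyphenyl group also reads like 3,4-dichlorophenyl, with a 1.1-fold lower number from compound 1 to compound 4 (0.06 log units; within the scatter) in that swap. Nothing at hand gives a reason for this flat picture. Still open, going by these compounds, is whether an amine or a carboxylic acid at this position, or a longer chain on the ring, would carry the number beyond the scatter.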